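A few compounds are considered here, and "the series" means these few. Any claim that something is new, unique, unknown or untested is made for them only; others in the source may bear on it.

Measured compounds in the series:

- compound 1, `COc1ccc(/C=N/NC(=O)Nc2ccc(Oc3ccnc(-c4nncn4CCN(C)C)c3)c(F)c2)c(OC)c1`: 1570 nM
- compound 2, `CN(C)CCn1cnnc1-c1cc(Oc2ccc(NC(=O)N/N=C/c3c(O)ccc4ccccc34)cc2F)ccn1`: 890 nM

Both numbers come from a functional assay on NCI-H460 cells (Homo sapiens) for cytotoxicity, read by MTT assay, with a stated time of 72 h; on this read-out lower numbers stand for stronger inhibition and higher numbers for weaker inhibition. On that read-out compound 2 stands at the lower of the two numbers, and its nearest neighbour is compound 1; the pair differs only at the carbon with a double bond to nitrogen, and the step of a 1.8-fold lower number from compound 1 to compound 2 (0.25 log units; within the scatter) is within the scatter, so no order between compound 1 and compound 2 can be claimed.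

Compound 3, `CN(C)CCn1cnnc1-c1cc(Oc2ccc(NC(=O)N/N=C/c3ccc(O)cc3O)cc2F)ccn1`, has not yet been measured in this assay. It differs from compound 2 at the same place: 2,4-dihydroxyphenyl in place of 2-hydroxynaphthalen-1-yl on a carbon with a double bond to nitrogen. For the measured compounds named here, the only measured step that bears on this position is a 1.8-fold lower number from compound 1 to compound 2 (0.25 log units; within the scatter), which did not leave the scatter; nothing measured here separates the aryl groups at this carbon. The change to compound 3 is therefore expected to give no step beyond the scatter, with a 1.3-fold higher number from compound 2 to compound 3 (0.13 log units; within the scatter) as the expected step, leaning slightly toward a higher number because compound 1 gave 1570 nM with a single ring at this carbon.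

For compound 3 the estimate in this assay is 1200 nM, with a range from 500 nM to 2900 nM.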

Compound 3, half-maximal inhibitory concentration: 11300 nM
Compound 3: the middle estimate sits 9.4-fold (0.97 log units) below what was measured; the measured number lies above the stated range.
By their numbers in this assay, from the lowest: compounds 2 and 1 (each within the scatter of the next); then compound 3.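

In this assay, for the compounds shown here, the aryl group on the carbon with a double bond to nitrogen now shows a clear effect: 2,4-dihydroxyphenyl in place of 2-hydroxynaphthalen-1-yl gives a 13-fold higher number from compound 2 to compound 3 (1.10 log units; beyond the scatter), the first step at this position beyond the scatter. Loss of the second aromatic ring cannot be the whole of that step, since 2,4-dihydroxyphenyl in place of 2,4-dimethoxyphenyl, with one ring on each side, still gives a 7.2-fold higher number from compound 1 to compound 3 (0.86 log units; beyond the scatter); a hydroxyl on the aryl group does not by itself go with the higher number either, as compound 2 carries one and stands with compound 1 at the low end. Nothing available explains either step.

Still open, from the compounds shown here alone, is whether the higher number needs both hydroxyl groups, which a 2-hydroxyphenyl or a 4-hydroxyphenyl group at this carbon would test, while an unsubstituted naphthalen-1-yl would separate the second ring from the hydroxyl in compound 2. Also open, going by these compounds, is how a phenyl group bearing an amine or a carboxylic acid would stand at this carbon.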